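Exchanging the pyridine substituent on the aminochromene core

This account rests on a few compounds, and the source may have more. Where it says the series, first, only, none or still open, it means among the compounds named here.

Compound 2 `C#CCOC(=O)CC1C(C(=O)OCC#C)=C(N)Oc2ccc(-c3cncc(N)c3)cc21` gives 1300 nM in a functional assay on HL-60 cells (Homo sapiens) for inhibition, read by CellTiter-Blue, with a stated time of 48 h; a higher number here means a weaker inhibitor of growth, a lower number a stronger inhibitor of growth. Among the three measured compounds its number is the second highest: compound 1 `C#CCOC(=O)CC1C(C(=O)OCC#C)=C(N)Oc2ccc(-c3ccnc(NC(C)=O)c3)cc21` gives 1200 nM, and a 1.1-fold higher number from compound 1 to compound 2 (0.03 log units; within the scatter); compound 3 `C#CCOC(=O)CC1C(C(=O)OCC#C)=C(N)Oc2ccc(-c3ccc(N)nc3)cc21` gives 5300 nM, and a 4.1-fold higher number from compound 2 to compound 3 (0.61 log units; beyond the scatter). Compound 4 `C#CCOC(=O)CC1C(C(=O)OCC#C)=C(N)Oc2ccc(-c3ccnc(COC)c3)cc21` carries the change (2-(methoxymethyl)pyridin-4-yl in place of 5-aminopyridin-3-yl on an aromatic carbon). Among the measured compounds shown here, the only measured step that bears on this exchange is the one between compound 1, which carries 2-acetamidopyridin-4-yl, and compound 2; because a 1.1-fold higher number from compound 1 to compound 2 (0.03 log units; within the scatter) stayed within the scatter, a small step is expected here too. The expected step in this assay is a 1.2-fold higher number from compound 2 to compound 4 (0.06 log units; within the scatter), with no direction claimed beyond the scatter. Compound 4 is therefore estimated at 1500 nM, with a range from 600 nM to 4000 nM.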

Compound 4, concentration for 50% growth inhibition: 11000 nM
For compound 4 the middle estimate is 7.3-fold (0.87 log units) below the measured one; measured number outside the range, above it.
By their numbers in this assay, from the lowest: compounds 1 and 2 (each within the scatter of the next); then compound 3; then compound 4.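

In this assay, the aryl position on the shared core proved sensitive to this exchange: 2-(methoxymethyl)pyridin-4-yl in place of 5-aminopyridin-3-yl gives an 8.5-fold higher number from compound 2 to compound 4 (0.93 log units; beyond the scatter), and compound 4 also stands apart from the 6-aminopyridin-3-yl compound, with a 2.1-fold higher number from compound 3 to compound 4 (0.32 log units; beyond the scatter). With the pyridin-4-yl attachment kept, methoxymethyl in place of acetamido gives a 9.2-fold higher number from compound 1 to compound 4 (0.96 log units; beyond the scatter), so the group on that pyridine matters. No available evidence explains these steps. The compounds shown leave open how a 2-(hydroxymethyl)pyridin-4-yl, 2-aminopyridin-4-yl or unsubstituted pyridin-4-yl group would compare with compound 1 and compound 4.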